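Notes on ethylating the piperazine nitrogen of compound 2

The source may hold more compounds than are shown below. What is called first, only, known or untested is meant among the compounds shown, and "the series" means these compounds.

Compound 2 `CNc1ncc2c(-c3ccc(N4CCNCC4)nc3)nn(Cc3cn(Cc4ccccc4)nn3)c2n1` carries the shared core with a benzyl-triazolylmethyl group on the ring nitrogen. In an assay for inhibition of tyrosine-protein kinase Mer (Homo sapiens), read by 33P incorporation, in the presence of a further agent that is not named here (on this read-out lower numbers stand for stronger inhibition and higher numbers for weaker inhibition), compound 2 gives 2300 nM, the highest of the two numbers reported; its nearest neighbour is compound 1 `CNc1ncc2c(-c3ccc(N4CCNCC4)nc3)nn(CC3CCCC3)c2n1`, which in this assay gives 640 nM, the step being a 3.6-fold higher number from compound 1 to compound 2 (0.56 log units; beyond the scatter). Compound 3 `CNc1ncc2c(-c3ccc(N4CCNCC4)cc3)nn(Cc3cn(Cc4ccccc4)nn3)c2n1` reaches only the limit of this assay, > 10000 nM. The step of an at least 4.3-fold higher number from compound 2 to compound 3 (0.63 log units; beyond the scatter) rests on that limit.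

Compound 4 `CCN1CCN(c2ccc(-c3nn(Cc4cn(Cc5ccccc5)nn4)c4nc(NC)ncc34)cn2)CC1` differs from compound 2 by ethyl in place of hydrogen on an amine nitrogen in a ring. Among the compounds with values here, both measured steps concern other parts of the molecule, the group on the ring nitrogen and the aryl ring, so neither bears directly on substitution at the amine nitrogen, and no measured pair shows what ethylation there does. In this assay the step of a 1.1-fold higher number from compound 2 to compound 4 (0.04 log units; within the scatter) is therefore expected to stay within the scatter, with no fixed direction. Compound 4 is estimated at 2500 nM in this assay, with a range of 900 nM to 7000 nM.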

Compound 4, half-maximal inhibitory concentration: > 10000 nM
Compound 4 gave a limit, no number (the forecaster's own chance of this, stated with the estimate: 8%); middle value at least 4.0-fold (0.60 log units) from the limit.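

Ethyl in place of hydrogen on the amine nitrogen of the piperazine ring is not a silent change in this assay, where the earlier compounds gave no reading at this position: the step is an at least 4.3-fold higher number from compound 2 to compound 4 (0.63 log units; beyond the scatter). Compound 4 gives > 10000 nM, which is a limit of the assay and not a number. The amine nitrogen therefore joins the group on the ring nitrogen and the aryl ring as a place where a single change moves the read-out beyond the scatter, but the step gives only a lower bound and compound 3 and compound 4 cannot be ordered: the limit of > 10000 nM in this assay, at which 2 of the 4 values shown sit.

From the compounds shown here alone, whether the weakening belongs to ethyl alone stays open, since a methyl, an acetyl or a longer chain ending in a hydroxyl group on the same nitrogen would show how it depends on the substituent. Also open, going by these compounds, is whether ethyl on this nitrogen acts the same way with the cyclopentyl group of compound 1.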